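Amide side chains: compound 3 to compound 4

The compounds below may be only part of what the source reports. "The series", "measured", "known", "first", "only" and "open" are said of these compounds alone.

Values in a functional assay on MDA-MB-231 cells (Homo sapiens) for antiproliferative activity, read by MTT assay, with a stated time of 48 h; on this read-out lower numbers stand for stronger inhibition and higher numbers for weaker inhibition:
- compound 1 `Cc1c(C(=O)NCCCN(C)C)oc2ccc(N(Cc3ccc(Br)cc3)S(=O)(=O)c3ccc(Br)cc3)cc12`: 6680 nM
- compound 2 `Cc1c(C(=O)NCC(O)CO)oc2ccc(N(Cc3ccc(Br)cc3)S(=O)(=O)c3ccc(Br)cc3)cc12`: 16500 nM
- compound 3 `Cc1ccc(NC(=O)c2oc3ccc(N(Cc4ccc(Br)cc4)S(=O)(=O)c4ccc(Br)cc4)cc3c2C)nc1`: > 40000 nM (a limit)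

Compound 3 stands at > 40000 nM, which is a limit of the assay and not a number. Compound 4 `Cc1c(C(=O)NCCNc2ccccc2)oc2ccc(N(Cc3ccc(Br)cc3)S(=O)(=O)c3ccc(Br)cc3)cc12` carries 2-anilinoethyl in place of 5-methylpyridin-2-yl on an amide-type nitrogen. For the measured compounds named here, two measured steps bear on this change, both into 5-methylpyridin-2-yl: an at least 5.9-fold higher number from compound 1 to compound 3 (0.77 log units; beyond the scatter) and an at least 2.4-fold higher number from compound 2 to compound 3 (0.38 log units; beyond the scatter). The two chains themselves differ by a 2.5-fold higher number from compound 1 to compound 2 (0.39 log units; beyond the scatter). A chain on that nitrogen is therefore expected to bring a modest step towards a lower number in this assay. The expected step is an at least 2.8-fold lower number from compound 3 to compound 4 (0.45 log units; beyond the scatter). The estimate for compound 4 is 14000 nM, with an expected range of 5000 nM to 40000 nM.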

Compound 4, half-maximal inhibitory concentration: > 40000 nM
Compound 4: a limit, no number; the forecaster's own chance of this, stated with the estimate: 20%; at least 2.8-fold (0.45 log units) between middle value and limit.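

In this assay compound 4 gives > 40000 nM, which is a limit of the assay. A saturated chain on the amide-type nitrogen therefore does not by itself secure a measurable value: with 2-anilinoethyl the steps are an at least 5.9-fold higher number from compound 1 to compound 4 (0.77 log units; beyond the scatter) and an at least 2.4-fold higher number from compound 2 to compound 4 (0.38 log units; beyond the scatter). The step between compound 3 and compound 4 cannot be read because both values are limits: the limit of > 40000 nM in this assay, at which 2 of the 4 values shown sit.

Open, from the compounds shown here alone, is whether the dimethylamino end of compound 1 accounts for its measurable value. Also open, going by these compounds, is how a 4-(dimethylamino)butyl chain or a chain ending in a carboxylic acid would read on this nitrogen.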